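Pyridine back on the ether chain, one carbon shorter

The compounds below may be only part of what the source reports. "The series", "measured", "known", "first", "only" and "open" are said of these compounds alone.

Compound 2 `CC(=O)SCC(=O)c1ccc(NS(=O)(=O)c2ccc(OCCCO)cc2)nc1` shows the highest number of the two measured in a functional assay on HCT-116 cells (Homo sapiens) for cytotoxicity; a higher number here means that more compound is needed for the effect, a lower number that less compound is needed: compound 2 gives 8600 nM, while compound 1 `CC(=O)SCC(=O)c1ccc(NS(=O)(=O)c2ccc(OCCc3ccccn3)cc2)nc1` gives 750 nM. Compound 3 `CC(=O)SCC(=O)c1ccc(NS(=O)(=O)c2ccc(OCc3ccccn3)cc2)nc1` differs from compound 2 by pyridin-2-yl in place of 2-hydroxyethyl on a saturated chain carbon bound to an oxygen on an aromatic ring. Among the compounds with values here, the one step that bears on it runs the other way: an 11-fold higher number from compound 1 to compound 2 (1.06 log units; beyond the scatter). The reverse exchange is therefore expected to give a lower number, roughly a 5.7-fold lower number from compound 2 to compound 3 (0.76 log units; beyond the scatter), with extra uncertainty because compound 3 carries the ring one bond closer to the ether oxygen than compound 1. Compound 3 is estimated at 1500 nM, within 450 nM to 5000 nM.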

Compound 3, half-maximal effective concentration: 420 nM
Compound 3: the middle estimate sits 3.6-fold (0.55 log units) above what was measured; measured number below the stated range.
By their numbers in this assay, from the lowest: compounds 3 and 1 (each within the scatter of the next); then compound 2.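

In this assay the exchange of 2-hydroxyethyl for pyridin-2-yl gives a 20-fold lower number from compound 2 to compound 3 (1.31 log units; beyond the scatter) and shows that the large gap to the alcohol also holds with the ring on the saturated chain carbon bound to the aromatic oxygen. Compound 1 and compound 3 cannot be told apart, as the exchange gives a 1.8-fold lower number from compound 1 to compound 3 (0.25 log units; within the scatter) and so the two pyridine-bearing chains read alike in this assay. The compounds shown leave open whether the ring nitrogen matters, which a phenyl group at this place would test. No supporting evidence accounts for these steps.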